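From an amine side chain to a branched ester

The source may report more compounds than this note shows. Statements on the series, on what has been measured and on what is new or still open speak of the compounds shown alone.

compound 1 `CCOC(=O)COc1ccc2c(=O)cc(-c3cc(C(C)(C)C)c(O)c(C(C)(C)C)c3)oc2c1`: 3000 nM
compound 2 `CN(C)CCCOc1ccc2c(=O)cc(-c3cc(C(C)(C)C)c(O)c(C(C)(C)C)c3)oc2c1`: 700 nM

Within the data shown here, in a functional assay for inhibition (a higher number here means a weaker inhibitor, a lower number a stronger inhibitor), compound 2 has the lower of the two numbers so far, which makes it the stronger inhibitor of the pair. Compound 3 `CCOC(=O)C(C)(C)Oc1ccc2c(=O)cc(-c3cc(C(C)(C)C)c(O)c(C(C)(C)C)c3)oc2c1` has not been measured yet. It differs from compound 2 as follows: 1-(ethoxycarbonyl)-1-methylethyl in place of 3-(dimethylamino)propyl on an oxygen on an aromatic ring. In words, 1-(ethoxycarbonyl)-1-methylethyl stands in place of 3-(dimethylamino)propyl on an oxygen on an aromatic ring. Among the measured compounds shown here, only one measured step bears on this: a 4.3-fold lower number from compound 1 to compound 2 (0.63 log units; beyond the scatter). Compound 3 also carries an ethoxycarbonyl group, so that modest step is expected to run largely in reverse, although no measurement covers the added methyl branch. The expected change, toward a higher number, is a 4.3-fold higher number from compound 2 to compound 3 (0.63 log units; beyond the scatter). Compound 3 is estimated at 3000 nM, with an expected range of 1000 nM to 9000 nM.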

Compound 3, half-maximal inhibitory concentration: 3000 nM
Compound 3: middle estimate and measured number agree at the digits printed; the range from low to high includes it.
By their numbers in this assay, from the lowest: compound 2; then compounds 1 and 3 (each within the scatter of the next).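

In this assay, the two ester groups on an oxygen on an aromatic ring read alike, with no change at the digits printed from compound 1 to compound 3 (within the scatter) when 1-(ethoxycarbonyl)-1-methylethyl stands in place of (ethoxycarbonyl)methyl. The gap to the amine side chain holds for this branched ester too, with a 4.3-fold higher number from compound 2 to compound 3 (0.63 log units; beyond the scatter) on going from 3-(dimethylamino)propyl to 1-(ethoxycarbonyl)-1-methylethyl, so among these three compounds the one amine has the lowest number and both esters sit higher. Nothing on hand explains these numbers.

Still open, as far as these compounds go, is whether the amine nitrogen or the length of its chain matters, which a shorter 2-(dimethylamino)ethyl chain or a morpholine on the same oxygen could help separate. Also open, from the compounds shown here alone, is how a free carboxylic acid in place of the ethyl ester would read in this assay.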